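From Butyl to Phenyl on a Shared Core

The source may hold more compounds than are shown below. What is called first, only, known or untested is meant among the compounds shown, and "the series" means these compounds.

Within the data shown here, only two compounds with this shared core have been measured so far. In a functional assay (mast cells) for inhibition, with Rattus norvegicus as the target (on this read-out higher numbers stand for an effect only at larger amounts of compound and lower numbers for an effect already at smaller amounts), compound 1 `CC(C)c1ccc(N/N=C2\CCC(C)n3c2ncc(C(=O)O)c3=O)cc1`, which carries isopropyl, gives 1200 nM, and compound 2 `CCCCc1ccc(N/N=C2\CCC(C)n3c2ncc(C(=O)O)c3=O)cc1`, which carries butyl, gives 1700 nM. Among the measured compounds shown here, the only measured step is a 1.4-fold higher number from compound 1 to compound 2 (0.15 log units; within the scatter). Compound 2 therefore stands level with compound 1, and these numbers cannot separate the pair.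

Compound 3 `CC1CC/C(=N\Nc2ccc(-c3ccccc3)cc2)c2ncc(C(=O)O)c(=O)n21` keeps the core and changes one group, with phenyl in place of butyl on an aromatic carbon. For the measured compounds named here, only the step between compound 1 and compound 2 bears on this change, and it swapped one carbon chain for another. Going by the values given here, no measured compound carries a ring at this place, so the evidence is thin. Going by that one small step, no shift beyond the scatter is expected in this assay, though a move in either direction remains open. The expected step is a 1.1-fold lower number from compound 2 to compound 3 (0.05 log units; within the scatter). For compound 3 the estimated value is 1500 nM, with an expected range from 500 nM to 4500 nM.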

Compound 3, half-maximal effective concentration: 4400 nM
The estimate for compound 3 lay 2.9-fold (0.47 log units) below the measured number; measured number inside the range.
By their numbers in this assay, from the lowest: compounds 1 and 2 (each within the scatter of the next); then compound 3.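

The swap of one carbon chain for another at this place left the number within the scatter, but phenyl brings a real change in this assay. Phenyl in place of butyl gives a 2.6-fold higher number from compound 2 to compound 3 (0.41 log units; beyond the scatter), and phenyl in place of isopropyl gives a 3.7-fold higher number from compound 1 to compound 3 (0.56 log units; beyond the scatter), both modest in size but beyond the scatter, so more of compound 3 is needed for the same effect. This position, on an aromatic carbon and para to a large group, therefore responds to the group placed on it, although nothing available here accounts for the shift.

Among these compounds, with only two chains and one ring to compare, these compounds cannot separate the effect of the aromatic ring from that of a group with more heavy atoms, a question that cyclohexyl, a six-membered ring of carbon that is not aromatic, could help to settle. Also open, as far as these compounds go, is whether a small group such as methyl, or one carrying other atoms, such as an amine or a methoxy group, would bring the number down or push it higher still.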